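Swapping Pyrrolidin-1-yl for Isopropylamino: Expected Cytotoxicity

The source may hold more compounds than are shown below. What is called first, only, known or untested is meant among the compounds shown, and "the series" means these compounds.

Compound 1 `Nc1nc(NC2CCCCC2)c2ncn(/C=C3/CC3(CO)CO)c2n1` — in an ADME assay on HFF cells (Homo sapiens) for cytotoxicity, with a stated time of 8 days (a lower number here means that less compound is tolerated, a higher number that more compound is tolerated), compound 1 gives only a limit, > 300000 nM.
Compound 2 `CCCNc1nc(N)nc2c1ncn2/C=C1/CC1(CO)CO` — in this assay compound 2 gives only a limit, > 300000 nM.
Compound 3 `Nc1nc(N2CCCC2)c2ncn(/C=C3/CC3(CO)CO)c2n1` — in this assay compound 3 gives only a limit, > 300000 nM.

Compound 3 therefore stands at the same place as the other two: none of the three compounds gives a number in this assay, and all three sit at the limit of > 300000 nM in this assay, at which 3 of the 3 values shown sit. The steps between them are accordingly unreadable: a step that the two limits leave unreadable from compound 1 to compound 2, a step that the two limits leave unreadable from compound 1 to compound 3 and a step that the two limits leave unreadable from compound 2 to compound 3.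

Compound 4 `CC(C)Nc1nc(N)nc2c1ncn2/C=C1/CC1(CO)CO` has not yet been measured in this assay. It differs from compound 3 in one place: isopropylamino in place of pyrrolidin-1-yl on an aromatic carbon. Going by the values given here, the step that bears most directly on this change is the one from compound 2 to compound 3, a step that the two limits leave unreadable from compound 2 to compound 3, in which a propylamino group was replaced by the same pyrrolidin-1-yl that now leaves; it gave no readable size, since both ends are limits. With every measured value resting at the same limit, no direction can be read from the data, and no step beyond the scatter is expected.

Compound 4 is therefore expected to give 300000 nM in this assay, with a range from 100000 nM to 1000000 nM, most likely again as a limit; the step from compound 3 is expected to be a number no higher from compound 3 to compound 4 (the limit leaves the size open).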

Compound 4, half-maximal cytotoxic concentration: > 300000 nM
Compound 4 ended at the assay's limit (the forecaster's own chance of this, stated with the estimate: 85%); the middle value sits exactly at the limit.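

In this assay compound 4 gives only a limit, > 300000 nM. The steps to compound 4 from compound 1, compound 2 and compound 3 therefore cannot be read, and all four compounds stand at the same place: the limit of > 300000 nM in this assay, at which 4 of the 4 values shown sit.

The compounds shown leave open how far each true value lies past this limit, and which change, if any, would yield a measurable number.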